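Chloro scan on the anilino ring of the pyrimidine series

The source may report more compounds than this note shows. Statements on the series, on what has been measured and on what is new or still open speak of the compounds shown alone.

Measured so far in an assay on isolated protein for inhibition of tyrosine-protein kinase receptor UFO (Homo sapiens), read by TR-FRET, with a stated time of 60 min; on this read-out higher numbers stand for weaker inhibition and lower numbers for stronger inhibition:
- compound 1 `CN1CCN(Cc2ccc(Nc3ncc(F)c(-c4ccc(F)cc4S(=O)(=O)N4CCCC4)n3)cc2)CC1`: 1150 nM
- compound 2 `CN1CCN(Cc2ccc(Nc3ncc(Cl)c(Nc4ccccc4S(=O)(=O)N4CCCC4)n3)cc2)CC1`: 19 nM

Compound 2 gives the lowest number of the two, and the gap to compound 1 lies beyond the scatter; the two structures differ in more than one place, so no single step can be read from them.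

Compound 3 `CN1CCN(Cc2ccc(Nc3ncc(Cl)c(Nc4ccc(Cl)cc4S(=O)(=O)N4CCCC4)n3)cc2)CC1` is not yet measured. It differs from compound 2 by chloro in place of hydrogen on an aromatic carbon, meta to the (pyrrolidin-1-yl)sulfonyl group and para to a large group.

Among the compounds with values here, no measured pair covers this change. With the sulfonyl-bearing ring otherwise kept as in compound 2, the expectation is a step that stays within the scatter or, at most, a small one, in either direction. The expected value for compound 3 in this assay is 15 nM (range 5 nM to 50 nM), which means an estimated step of a 1.3-fold lower number from compound 2 to compound 3 (0.10 log units; within the scatter).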

Compound 3, half-maximal inhibitory concentration: 1080 nM
Estimate against measurement, compound 3: 72-fold (1.86 log units) below; measured number above the stated range.
By their numbers in this assay, from the lowest: compound 2; then compounds 3 and 1 (each within the scatter of the next).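

In this assay, within the data shown here, chloro in place of hydrogen on an aromatic carbon, meta to the (pyrrolidin-1-yl)sulfonyl group and para to a large group, gives a 57-fold higher number from compound 2 to compound 3 (1.75 log units; beyond the scatter) and so provides the first single-place step. This position is therefore far from indifferent: one added chlorine atom, with the rest of compound 2 unchanged, is enough for a large step towards weaker inhibition. Nothing measured on these compounds bears on the reason for this step.

Still open, as far as these compounds go, is whether the step belongs to chloro itself or to any group on this carbon, which fluoro, methyl or methoxy there would help to separate. Also open, from the compounds shown here alone, is how chloro behaves on the other free carbons of this ring; compound 1 and compound 2 differ in more than one place and give no readable step.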